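Hydroxy to Amino on a Stilbene: Expected Step for Compound 4

A few compounds are considered here, and "the series" means these few. Any claim that something is new, unique, unknown or untested is made for them only; others in the source may bear on it.

Of the compounds shown here, three have been tested in a functional assay on HT-29 cells (Homo sapiens) for inhibition, read by MTT assay, with a stated time of 2 days; a lower number here means a stronger inhibitor, a higher number a weaker inhibitor. Compound 1 `COc1ccc(/C=C/c2ccccc2O)cc1` gives 10 ug/mL. Compound 2 `COc1ccccc1/C=C/c1cccc(O)c1` has a core that differs from that of compound 1 in a way that is not broken down here; in this assay compound 2 gives 17 ug/mL. Compound 3 `COc1ccc(/C=C/c2ccccc2N)cc1` gives 73 ug/mL. The change amino in place of hydroxy on an aromatic carbon produced the step of a 7.3-fold higher number from compound 1 to compound 3 (0.86 log units; beyond the scatter). Compound 4 `COc1ccccc1/C=C/c1cccc(N)c1` carries the same kind of change relative to compound 2, (amino in place of hydroxy on an aromatic carbon), though here the group sits meta to a large group rather than ortho to a large group. Among the measured compounds shown here, because the only measured instance of this change is a 7.3-fold higher number from compound 1 to compound 3 (0.86 log units; beyond the scatter), a step of comparable size is expected, namely a 5.9-fold higher number from compound 2 to compound 4 (0.77 log units; beyond the scatter). Compound 4 is therefore expected to give about 100 ug/mL in this assay, with a likely range from 40 ug/mL to 250 ug/mL.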

Compound 4, half-maximal inhibitory concentration: 25.3 ug/mL
Beside the measured number, compound 4's estimate is 4.0-fold (0.60 log units) above it, and the stated range ends above it.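

On the core of compound 2, amino in place of hydroxy on an aromatic carbon gives a 1.5-fold higher number from compound 2 to compound 4 (0.17 log units; within the scatter) in this assay. Set beside the earlier step, this shows that the size of the change does not carry over from one core to the other in this series: the same change on two cores in this assay, a 7.3-fold higher number (0.86 log units; beyond the scatter) from compound 1 to compound 3 and a 1.5-fold higher number (0.17 log units; within the scatter) from compound 2 to compound 4, 4.9-fold (0.69 log units) apart, beyond the scatter of two such steps With only two such pairs, it does not show which difference between the cores sets the size of the step, or whether the place of the group, meta to a large group in compound 4, plays any part.

The compounds shown leave open how the same change would read on further cores. They also leave open how a fluorine or a carboxylic acid in that place would compare in this assay.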